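The source may report more compounds than this note shows. Statements on the series, on what has been measured and on what is new or still open speak of the compounds shown alone.

Measured compounds:
compound 1, `CC1CCN(c2c(S(=O)(=O)c3cc(Cl)cc(Cl)c3)cnc3c(F)cccc23)CC1`, 82%
compound 2, `CC1CCN(c2c(S(=O)(=O)c3ccc(Cl)c(Cl)c3)cnc3c(F)cccc23)CC1`, 95%

In an assay on isolated protein for displacement of a labelled ligand from metabotropic glutamate receptor 5 (Homo sapiens), with a stated time of 60 min, tested at 1 uM (on this read-out higher numbers stand for more inhibition at the one concentration tested (going by the name of the read-out) and lower numbers for less inhibition), compound 2 gives 95%, the higher of the two numbers shown; compound 1 gives 82%. Within the data shown here, the only measured step, a number 13 percentage points higher from compound 1 to compound 2 (beyond the scatter), lies beyond the scatter and is modest. Compound 3, `CC1CCN(c2c(S(=O)(=O)c3cccc(F)c3)cnc3c(F)cccc23)CC1`, has not yet been measured; it differs from compound 2 by 3-fluorophenyl in place of 3,4-dichlorophenyl on a sulfonyl sulfur. Among the measured compounds shown here, no measured step replaces a dichlorophenyl with a monofluorophenyl, so the step from compound 1 to compound 2 bears on this change only loosely: it shows that rearranging the substituents on this ring shifts the read-out by a modest amount. Exchanging the ring itself is expected to shift the read-out further, and downward. Compound 3 is therefore expected to give 60%, within the range 25% to 90%. A step of a number 35 percentage points lower from compound 2 to compound 3 (beyond the scatter) is expected.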

Compound 3, a percentage reported as inhibition, at one concentration (the size of the read-out at that concentration, not a potency): 62%
The estimate for compound 3 lay 2 percentage points below the measured number; measured number inside the range.
By their numbers in this assay, from the lowest: compound 3; then compound 1; then compound 2.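

Exchanging the whole ring on the sulfonyl sulfur moves the result in this assay much more than the earlier rearrangement of chlorines did: 3-fluorophenyl in place of 3,4-dichlorophenyl gives a number 33 percentage points lower from compound 2 to compound 3 (beyond the scatter) and marks a large step. In place of 3,5-dichlorophenyl, the same group gives a number 20 percentage points lower from compound 1 to compound 3 (beyond the scatter) and marks a modest one. Among these three compounds, therefore, both dichlorophenyl groups stand above 3-fluorophenyl, and the position responds to the ring's halogen substitution as well as to where the chlorines sit.

Because fluorine replaces chlorine here while the number of halogens also falls, these compounds cannot separate the two changes, and a monochlorophenyl or a plain phenyl ring would bear directly on that question. No measurement at hand explains the fall at this position.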